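Shortening the Ketone Side Chain on a Shared Core

A few compounds are considered here, and "the series" means these few. Any claim that something is new, unique, unknown or untested is made for them only; others in the source may bear on it.

Compound 1 `CCOC(=O)N1CCN(CCCOc2ccc(C(C)=O)cc2)CC1`: 39800 nM
Compound 2 `CCCCCCCCC(=O)c1ccc(OCCCN2CCN(C(=O)OCC)CC2)cc1`: 2690 nM

In an assay on isolated protein for binding affinity to histamine H2 receptor (Homo sapiens) (a higher number here means a weaker inhibitor, a lower number a stronger inhibitor), compound 2 has the lowest number of the two, and the step of a 15-fold lower number from compound 1 to compound 2 (1.17 log units; beyond the scatter) is the only one measured. Compound 3 `CCOC(=O)N1CCN(CCCOc2ccc(C(=O)C3CC3)cc2)CC1` differs from compound 2 by cyclopropyl in place of octyl on a carbonyl carbon. Because the step of a 15-fold lower number from compound 1 to compound 2 (1.17 log units; beyond the scatter) was large and went with a much longer group on the carbonyl carbon, the shorter cyclopropyl is expected to give back part of that gain. Compound 3 is therefore expected to show a 5.6-fold higher number from compound 2 to compound 3 (0.75 log units; beyond the scatter). For compound 3 the estimate is 15000 nM, with a range from 5000 nM to 40000 nM.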

Compound 3, inhibition constant: 79400 nM
Beside the measured number, compound 3's estimate is 5.3-fold (0.72 log units) below it, and the stated range ends below it.
By their numbers in this assay, from the lowest: compound 2; then compounds 1 and 3 (each within the scatter of the next).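

On the carbonyl carbon, cyclopropyl in place of octyl gives a 30-fold higher number from compound 2 to compound 3 (1.47 log units; beyond the scatter) in this assay and so loses the whole advantage of compound 2. The step of a 2.0-fold higher number from compound 1 to compound 3 (0.30 log units; within the scatter) comes from cyclopropyl in place of methyl, so the small ring offers no measurable gain over methyl. Of these three groups, only octyl stands apart. No supporting data explain this result. From the compounds shown here alone, whether the advantage grows steadily with chain length or needs the full octyl stays open, as does the effect of a butyl chain or a cyclohexyl group here.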